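A Dimethylamino Variant of Compound 3

This account rests on a few compounds, and the source may have more. Where it says the series, first, only, none or still open, it means among the compounds named here.

Three ureas built on one shared core have been measured in an assay on microsomes for inhibition of acyl-CoA:cholesterol acyltransferase (Oryctolagus cuniculus); a lower number here means a stronger inhibitor, a higher number a weaker inhibitor. Compound 1 `Cc1ccccc1C1(CNC(=O)Nc2c(C(C)C)cccc2C(C)C)CCCC1` gives 17 nM, compound 2 `CC(C)c1cccc(C(C)C)c1NC(=O)NCC1(c2ccc(F)cc2)CCCC1` gives 23 nM, and compound 3 `CC(C)c1cccc(C(C)C)c1NC(=O)NCC1(c2ccc(N)cc2)CCCC1` gives 29 nM. Compound 3 has the highest of the three numbers, with compound 2 nearest and compound 1 furthest, yet both gaps lie within the scatter, so the three compounds cannot be told apart on these data. The next compound, compound 4 `CC(C)c1cccc(C(C)C)c1NC(=O)NCC1(c2cccc(N(C)C)c2)CCCC1`, differs from compound 3 by 3-(dimethylamino)phenyl in place of 4-aminophenyl on a saturated ring carbon. All three earlier steps change the same part of the molecule: a 1.4-fold higher number from compound 1 to compound 2 (0.13 log units; within the scatter), a 1.7-fold higher number from compound 1 to compound 3 (0.23 log units; within the scatter) and a 1.3-fold higher number from compound 2 to compound 3 (0.10 log units; within the scatter). Each stayed within the scatter, so for compound 4 no step beyond the scatter is expected in this assay, in either direction. Compound 4 is therefore estimated at 30 nM, with a range from 12 nM to 75 nM. The expected change is a 1.0-fold higher number from compound 3 to compound 4 (0.01 log units; within the scatter).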

Compound 4, half-maximal inhibitory concentration: 33 nM
Compound 4: the middle estimate sits 1.1-fold (0.04 log units) below what was measured; the range from low to high includes it.
By their numbers in this assay, from the lowest: compounds 1, 2, 3 and 4 (each within the scatter of the next).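

In this assay, 3-(dimethylamino)phenyl on the saturated ring carbon, with 9 heavy atoms and no hydrogen-bond donor against the 7 heavy atoms and single donor of 4-aminophenyl, gives a 1.1-fold higher number from compound 3 to compound 4 (0.06 log units; within the scatter). The comparisons with the other two aromatic groups read the same way, a 1.4-fold higher number from compound 2 to compound 4 (0.16 log units; within the scatter) and a 1.9-fold higher number from compound 1 to compound 4 (0.29 log units; within the scatter), so this place has now taken four different substituted phenyl groups with no step beyond the scatter, and the four compounds still cannot be told apart. Nothing available bears on this result.

The step swaps 4-aminophenyl for 3-(dimethylamino)phenyl in one move, so the compounds shown leave open what the two methyl groups or the placing of the amine would do alone. On these data alone, whether a carboxylic acid on the phenyl ring would move the number beyond the scatter also stays open.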